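A few compounds are considered here, and "the series" means these few. Any claim that something is new, unique, unknown or untested is made for them only; others in the source may bear on it.

Of the compounds shown here, three sharing one core have been measured in an ADME assay on HepG2 cells (Homo sapiens) for cytotoxicity, read by luminescence, CellTiter-Glo and ATP content, with a stated time of 72 h; a lower number here means that less compound is needed, a higher number that more compound is needed for the effect. Compound 1 `Fc1ccc(Cc2ccc3c(NCCCNCc4ccco4)ccnc3c2)cc1` gives 5600 nM. Compound 2 `COc1cccc(Oc2ccc3c(NCCCNCc4ccco4)ccnc3c2)c1` gives 15500 nM. Compound 3 `c1coc(CNCCCNc2ccnc3cc(C4CCCCC4)ccc23)c1` gives 4760 nM, the lowest of the three numbers; its nearest neighbour is compound 1, with a 1.2-fold lower number from compound 1 to compound 3 (0.07 log units; within the scatter), and the furthest is compound 2, with a 3.3-fold lower number from compound 2 to compound 3 (0.51 log units; beyond the scatter).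

Compound 4 `c1ccc(Cc2ccc3c(NCCCNCc4ccco4)ccnc3c2)cc1` has not yet been measured in this assay. It differs from compound 3 in one place: benzyl in place of cyclohexyl on an aromatic carbon. The measured step that bears most on this change is a 1.2-fold lower number from compound 1 to compound 3 (0.07 log units; within the scatter), where 4-fluorobenzyl gave way to cyclohexyl without moving the number beyond the scatter. Benzyl resembles 4-fluorobenzyl closely, so compound 4 is expected to sit near compound 1, and no step beyond the scatter is expected on going from compound 3 to compound 4. The expected step is a 1.2-fold higher number from compound 3 to compound 4 (0.06 log units; within the scatter). Compound 4 is therefore estimated at 5500 nM, with a range from 2500 nM to 12000 nM.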

Compound 4, half-maximal effective concentration: 16000 nM
Compound 4: the middle estimate sits 2.9-fold (0.46 log units) below what was measured; measured number above the stated range.
By their numbers in this assay, from the lowest: compounds 3 and 1 (each within the scatter of the next); then compounds 2 and 4 (each within the scatter of the next).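

In this assay, this position proves sensitive to a very small edit: hydrogen in place of fluoro gives a 2.9-fold higher number from compound 1 to compound 4 (0.46 log units; beyond the scatter) and so 4-fluorobenzyl cannot be treated as a stand-in for benzyl. Benzyl in place of cyclohexyl now also gives a step beyond the scatter, a 3.4-fold higher number from compound 3 to compound 4 (0.53 log units; beyond the scatter) even though 4-fluorobenzyl and cyclohexyl could not be told apart, while benzyl and 3-methoxyphenoxy cannot be told apart either, with a 1.0-fold higher number from compound 2 to compound 4 (0.01 log units; within the scatter) as their step. Nothing measured here explains why removing the fluoro has this effect.

Going by these compounds, whether a chloro or a methoxy group in the place of the fluoro would behave like fluoro or like hydrogen stays open. On these data alone, it is also open how an amine or a longer carbon chain on this aromatic carbon would compare.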